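This account rests on a few compounds, and the source may have more. Where it says the series, first, only, none or still open, it means among the compounds named here.

In an ADME assay on a cell-free system (plasma, Homo sapiens) for metabolic stability, tested at 1 uM (on this read-out higher numbers stand for a longer-lived compound and lower numbers for a shorter-lived compound), compound 3 (`C=CC(=O)NC1CCN(S(=O)(=O)c2ccc(C(=O)NCc3ccccc3)cc2)CC1`) gives only a limit (> 6 h) and no number. Compound 1 (`C=CC(=O)N[C@H]1CCN(S(=O)(=O)c2ccc(NC(=O)OCc3ccccc3)cc2)C1`) likewise gives a limit (> 6 h) and no number. Compound 2 (`C=CC(=O)N[C@@H]1CCN(S(=O)(=O)c2ccc(NC(=O)OCc3ccccc3)cc2)C1`) also gives a limit (> 6 h) and no number. The readings thus come to the limit of > 6 h in this assay, at which 3 of the 3 values shown sit, and nothing finer.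

Compound 4 (`C=CC(=O)NC1CCN(S(=O)(=O)c2ccc(C(=O)NC3CCCc4ccccc43)cc2)CC1`) differs from compound 3 by 1,2,3,4-tetrahydronaphthalen-1-yl in place of benzyl on an amide-type nitrogen in a single place, with 1,2,3,4-tetrahydronaphthalen-1-yl in place of benzyl on an amide-type nitrogen. Going by the values given here, the only measured step is a step that the two limits leave unreadable from compound 1 to compound 2 and it rests on the fact that compounds 1 and 2 differ only in the configuration as drawn so it offers no size for this change. No step beyond the scatter is therefore expected in this assay and no direction can be named. Compound 3 sits at its limit (> 6 h) and that is the sole anchor for the expectation. The estimated step is a step that the limit leaves unreadable from compound 3 to compound 4 in size. For compound 4 the expected half-life is 8 h with an estimated range from 4 h to 20 h and a further limit is the likeliest report.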

Compound 4, half-life: > 6 h
Compound 4 gave a limit, no number (the forecaster's own chance of this, stated with the estimate: 85%); the middle value lies beyond the limit too.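

Compound 3 and compound 4 both give only a limit in this assay, and no step can be read between them. The compounds shown leave open what the actual half-life of any of them is, and whether 1,2,3,4-tetrahydronaphthalen-1-yl in place of benzyl changes it at all.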